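The source may hold more compounds than are shown below. What is called first, only, known or untested is meant among the compounds shown, and "the series" means these compounds.

Working notes on the series. In a functional assay on MIA PaCa-2 cells (Homo sapiens) for inhibition, read by MTT assay, with a stated time of 72 h (on this read-out higher numbers stand for weaker inhibition and lower numbers for stronger inhibition), compound 3 (`COc1cc(NC(C)CCCNC(=O)Nc2ccc(F)cc2)c2ncccc2c1`) gives 21000 nM and lies within the scatter of both other measured compounds. In this assay compound 1 (`COc1cc(NC(C)CCCNC(=O)Nc2cccc(F)c2)c2ncccc2c1`) gives 22000 nM and compound 2 (`COc1cc(NC(C)CCCNC(=O)NNC(=O)Nc2ccc(C(F)(F)F)cc2)c2ncccc2c1`) gives 19000 nM so the three numbers form a single flat group.

Compound 4 (`COc1cc(NC(C)CCCNC(=O)Nc2cccc(C(F)(F)F)c2)c2ncccc2c1`) carries 3-(trifluoromethyl)phenyl in place of 4-fluorophenyl on an amide-type nitrogen and keeps the rest of compound 3 unchanged.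

Within the data shown here, one measured step bears directly on this place: a 1.0-fold lower number from compound 1 to compound 3 (0.02 log units; within the scatter) which exchanges 3-fluorophenyl for 4-fluorophenyl on the same nitrogen. Among the measured compounds shown here, no measured step exchanges a fluorine for a trifluoromethyl group on this scaffold, so the evidence is indirect. Compound 2 also bears a trifluoromethyl group but differs from compound 3 in more than one place, and compound 2 still gives 19000 nM in the same range as the others.

On these grounds no change beyond the scatter is expected in this assay for this exchange. The expected size is a 1.2-fold lower number from compound 3 to compound 4 (0.07 log units; within the scatter) as an estimate only. For compound 4 the estimated value is 18000 nM with an expected range of 8000 nM to 35000 nM on this read-out.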

Compound 4, half-maximal inhibitory concentration: 17000 nM
Estimate against measurement, compound 4: 1.1-fold (0.02 log units) above; measured number inside the range.
By their numbers in this assay, from the lowest: compounds 4, 2, 3 and 1 (each within the scatter of the next).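

In this assay, among these compounds, the exchange on the amide-type nitrogen gives a 1.2-fold lower number from compound 3 to compound 4 (0.09 log units; within the scatter), the first measured step on this scaffold that puts 3-(trifluoromethyl)phenyl in place of 4-fluorophenyl, and it does not separate the two compounds. The cleaner comparison, trifluoromethyl in place of fluoro on an aromatic carbon, gives a 1.3-fold lower number from compound 1 to compound 4 (0.11 log units; within the scatter), so at this position neither the exchange of the two groups nor the combined exchange of group and printed position takes the number outside the scatter in the compounds shown. No accompanying measurement bears on why these exchanges leave the number in the same range.

All the compounds shown keep the shared core and remain in one group of numbers, so it stays open whether any change on this phenyl ring can move the number beyond the scatter in this cell assay. An amine or a carboxylic acid on the phenyl ring, or a longer chain between the core and the amide-type nitrogen, would show whether this insensitivity extends beyond fluoro and trifluoromethyl.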